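Trading phenoxy for methylsulfanyl on a weakly active compound

This account rests on a few compounds, and the source may have more. Where it says the series, first, only, none or still open, it means among the compounds named here.

In a functional assay on MCF7 cells (Homo sapiens) for antiproliferative activity, read by sulforhodamine B assay, with a stated time of 3 days (on this read-out lower numbers stand for stronger inhibition and higher numbers for weaker inhibition), compound 1 (`Clc1ccc(Sc2ncnc3[nH]cnc23)c(Cl)c1`) gives 21400 nM and compound 2 (`c1ccc(Oc2ncnc3c2ncn3C2COc3ccccc3CO2)cc1`) gives 24700 nM as its result, so these two stand level within the usual scatter of repeated measurements. Compound 3 (`CSc1ncnc2c1ncn2C1COc2ccccc2CO1`) has not yet been measured. It keeps the core of compound 2 but carries methylsulfanyl in place of phenoxy on an aromatic carbon of a six-membered aromatic ring with 2 nitrogen (methylsulfanyl in place of phenoxy on an aromatic carbon). This swaps a ring-bearing group for a small one with no ring. Among the compounds with values here, the two measured compounds differ in more than one place, so no single-change step exists to show what such a swap does, and its size can only be judged. Compound 2 at 24700 nM is the closest guide, and from it a step in this assay no larger than the scatter, in neither direction, is expected. The estimated change is a 1.2-fold lower number from compound 2 to compound 3 (0.09 log units; within the scatter) at the centre of that expectation. Compound 3 is estimated at 20000 nM with a likely range of 7000 nM to 55000 nM in this measurement.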

Compound 3, half-maximal inhibitory concentration: 24000 nM
Compound 3: middle estimate off by 1.2-fold (0.08 log units), on the low side, within the range that was stated.
By their numbers in this assay, from the lowest: compounds 1, 3 and 2 (each within the scatter of the next).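

In this assay, within the data shown here, the first single-change comparison at this position gives a 1.0-fold lower number from compound 2 to compound 3 (0.01 log units; within the scatter) and places compound 2 and compound 3 level with each other. On this aromatic carbon next to the ring nitrogen, phenoxy, with its six-membered aromatic ring of carbon only, can give way to methylsulfanyl, which has no ring, while the result stays within the scatter, so in this pair the ring of phenoxy is not needed to hold this weak level of activity. The data shown offer no measurement that would explain why these two compounds stand level.

As far as these compounds go, both groups compared here are neutral and carry one hydrogen-bond acceptor, so it remains open whether an amine, a carboxylic acid or a longer chain such as n-butylsulfanyl on this same carbon would give a result beyond the scatter, in either direction. Also open, from the compounds shown here alone, is whether swapping phenoxy for methylsulfanyl would give a similar result on a different core, since this single pair shares one core and one level of weak activity.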